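Cytotoxicity notes: shortening the cationic chain on the guanidine analogue

This account rests on a few compounds, and the source may have more. Where it says the series, first, only, none or still open, it means among the compounds named here.

Compound 3 `CCN(CC)CC[n+]1c(SCC(=O)NCCNC(=N)N)[nH]c2c(C)nc(N(CC)CC)nc21` carries the guanidine-terminated amide side chain. In an ADME assay on CEM174 cells (Homo sapiens) for cytotoxicity (on this read-out lower numbers stand for higher toxicity in this test and higher numbers for lower toxicity in this test), compound 3 gives only a limit, > 100 uM. Compound 1 `CCN(CC)c1nc(C)c2[nH]c(SCC(=O)NCCN)[n+](CCCN(C)C)c2n1` likewise reaches only a limit in this assay, > 100 uM. Compound 2 `CCN(CC)c1nc(C)c2[nH]c(SCC(=O)NCCCN)[n+](CCCN(C)C)c2n1` again returns a limit in this assay, > 100 uM. All three sit at the limit of > 100 uM in this assay, at which 3 of the 3 values shown sit, so compound 3 stands level with the rest of the series as far as the numbers reach. Going by the values given here, the one step that can be traced, a step that the two limits leave unreadable from compound 1 to compound 2, is left unreadable by the two limits. Compound 4 `CCN(CC)c1nc(C)c2[nH]c(SCC(=O)NCCNC(=N)N)[n+](CCCN(C)C)c2n1` differs from compound 3 by (dimethylamino)methyl in place of diethylamino on a saturated chain carbon, two bonds along the chain from an aromatic nitrogen. Among the compounds with values here, no measured step concerns this change, and the only traced step gives no size to lean on. The expectation for this assay is therefore a step that the limit leaves unreadable from compound 3 to compound 4, nothing beyond the scatter, and most likely another limit. Compound 4 is expected to give 150 uM, within 60 uM to 400 uM.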

Compound 4, half-maximal toxic concentration: > 100 uM
Compound 4 was reported as a limit (the forecaster's own chance of this, stated with the estimate: 85%); the middle value does not contradict the limit.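

Compound 4 gives only a limit in this assay, as do compound 1, compound 2 and compound 3, so none of the steps to compound 4 can be read: the limit of > 100 uM in this assay, at which 4 of the 4 values shown sit.

The compounds shown leave open the actual toxic concentration of each compound, and so whether any of these changes alters it.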